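This account rests on a few compounds, and the source may have more. Where it says the series, first, only, none or still open, it means among the compounds named here.

Measured compounds:
- compound 1, `Cc1cnn(C(=O)N2CCCN(Cc3ccc(OCc4ccccc4)cc3)CC2)c1`, 9500 nM
- compound 2, `CN(CCN(C)C(=O)n1cc(C#N)cn1)Cc1ccc(OCc2ccccc2)cc1`, 320 nM
- compound 3, `Cc1cnn(C(=O)N(C)CCN(C)Cc2cccc(OCc3ccccc3)c2)c1`, 8300 nM

In an assay on membranes from brain for binding affinity to Monoacylglycerol lipase ABHD6 (Mus musculus), read by fluorescence, with stated times of 1 h and 30 min (a higher number here means a weaker inhibitor, a lower number a stronger inhibitor), compound 3 stands second highest of the three numbers. Its nearest neighbour is compound 1, whose number lies within the scatter of that of compound 3; compound 2 lies furthest away, with a number well below, beyond the scatter. Compound 4, `CN(CCN(C)C(=O)n1cccn1)Cc1cccc(OCc2ccccc2)c1`, differs from compound 3 by hydrogen in place of methyl on an aromatic carbon. No step of this kind has been measured among the shown compounds, so the account rests on compound 3 alone. The step from compound 3 to compound 4 is expected to be small and probably not beyond the scatter, a 1.2-fold higher number from compound 3 to compound 4 (0.08 log units; within the scatter). Compound 4 is therefore estimated at 10000 nM, with a range from 3000 nM to 30000 nM.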

Compound 4, half-maximal inhibitory concentration: 5500 nM
The estimate for compound 4 lay 1.8-fold (0.26 log units) above the measured number; measured number inside the range.
By their numbers in this assay, from the lowest: compound 2; then compounds 4, 3 and 1 (each within the scatter of the next).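

The exchange of 4-methyl-1H-pyrazol-1-yl for 1H-pyrazol-1-yl is the only single-place step among these compounds in this assay and gives a reading at this position (a 1.5-fold lower number from compound 3 to compound 4 (0.18 log units; within the scatter)). On the core of compound 3, this assay therefore does not tell hydrogen from methyl at this aromatic carbon. No measured property bears on this result, and the data offer no explanation for it. On these data alone, it remains open whether a methoxy group, an amine or a longer chain at this carbon would also stay within the scatter. As far as these compounds go, whether the same step holds on the core of compound 1 is also open.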